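The compounds below may be only part of what the source reports. "The series", "measured", "known", "first", "only" and "open" are said of these compounds alone.

Measured compounds in a functional assay on L1210 cells (Mus musculus) for inhibition, read by thymidine incorporation, tested at 10 uM; on this read-out higher numbers stand for a stronger effect at the one concentration tested and lower numbers for a weaker effect:

compound 1 `CC1(C)OC[C@H](COc2nc(N3CCCCC3)c3nc(OC[C@H]4COC(C)(C)O4)nc(N4CCCCC4)c3n2)O1` — 87%
compound 2 `CN(Cc1ccccc1)c1nc(OCCO)nc2c(N(C)Cc3ccccc3)nc(OCCO)nc12` — 87%
compound 3 `COC[C@H](COc1nc(N2CCCCC2)c2nc(OC[C@H](COC)OC)nc(N3CCCCC3)c2n1)OC` — 100%

Compound 3 stands highest of the three numbers in this assay. Compound 1 and compound 2 both sit lower by a gap that is beyond the usual scatter of this kind of measurement, so compound 3 can be called the strongest of the measured set on this read-out. Compound 1 and compound 2 give the same value as each other, and no order between them can be read from the data.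

The next compound, compound 4 `COCC(COc1nc(N2CCCCC2)c2nc(OCC(COC)OC)nc(N3CCCCC3)c2n1)OC`, has not yet been measured in this assay. Its relation to compound 3 is as follows: the two compounds have the same atoms and bonds; at least one stereo element is drawn with a configuration in one of them and without one in the other: 2 of 2 stereo elements differ; a stereocentre at a saturated chain carbon is drawn R in compound 3 and without a configuration in compound 4; a stereocentre at a saturated chain carbon is drawn S in compound 3 and without a configuration in compound 4. Among the measured compounds shown here, no pair of measured compounds differs in one place, so no measured step is available as a guide for this change.

For the measured compounds named here, since the atoms and bonds are identical and only the drawn configuration at the two stereocentres is absent in compound 4, no step beyond the scatter is expected in this assay; if anything, a small shift downward is conceivable, as the sample without drawn configuration may contain forms other than the one of compound 3. Compound 4 is therefore expected to give about 93% in this assay, within 75% to 100%. The step implied by this estimate, a number 7 percentage points lower from compound 3 to compound 4 (within the scatter), is expected to fall within the scatter.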

Compound 4, a percentage reported as inhibition, at one concentration (the size of the read-out at that concentration, not a potency): 87%
The estimate for compound 4 lay 6 percentage points above the measured number; the range from low to high includes it.
By their numbers in this assay, from the lowest: compounds 1, 2 and 4 (each within the scatter of the next); then compound 3.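

In this assay the series now has its first step at a single place, a number 13 percentage points lower from compound 3 to compound 4 (beyond the scatter), and it comes with no change in atoms or bonds. Among the compounds shown here, the earlier compounds offered no such comparison, so this is the first sign that the drawn configuration at the two stereocentres on the saturated chain carbons bears on the read-out, although the step is modest. The step can be assigned only to stereochemistry because nothing else separates the pair: the fact that one of compounds 3 and 4 is drawn with a defined configuration and the other without, at the place where they differ

Going by these compounds, it remains open which forms the sample of compound 4 contains, and whether the R and S centres count equally or one of them carries the step, since both differ at once and the read-out gives the size of an effect at one concentration rather than a potency. Also open, on these data alone, is whether the same sensitivity to configuration would persist with a carboxylic acid or a longer chain in place of the methoxy ends of the side chains.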